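Replacing the propoxycarbonyl group of compound 2

A few compounds are considered here, and "the series" means these few. Any claim that something is new, unique, unknown or untested is made for them only; others in the source may bear on it.

Measured in an ADME assay on a cell-free system (plasma, Homo sapiens) for metabolic stability, read by LC-MS; on this read-out higher numbers stand for a longer-lived compound and lower numbers for a shorter-lived compound:
- compound 1 `NCc1ccc(C(=O)Nc2ccncc2F)cc1-c1cccc(NC(=O)c2cccc(C(=O)O)c2)c1`: > 2 h
- compound 2 `CCCOC(=O)c1cccc(C(=O)Nc2cccc(-c3cc(C(=O)Nc4ccncc4F)ccc3CN)c2)c1`: < 0.0834 h
- compound 3 `CCCCOC(=O)c1cccc(NC(=O)c2cccc(-c3cc(C(=O)Nc4ccncc4F)ccc3CN)c2)c1`: < 0.0834 h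

Compound 2 gives only a limit, < 0.0834 h. Compound 3 also gives only a limit, < 0.0834 h. Compound 1 likewise gives only a limit, > 2 h.

Compound 4 `NCc1ccc(C(=O)Nc2ccncc2F)cc1-c1cccc(NC(=O)c2cc(C(=O)O)ccc2F)c1` differs from compound 2 as follows: 5-carboxy-2-fluorophenyl in place of 3-(propoxycarbonyl)phenyl on a carbonyl carbon. Compound 4 regains the carboxy group of compound 1, so the step that bears on it is an at least 23-fold lower number from compound 1 to compound 2 (1.37 log units; beyond the scatter), here run in reverse. Within the data shown here, no measured step covers the fluoro part of 5-carboxy-2-fluorophenyl. A large rise in this assay is therefore expected, an at least 35-fold higher number from compound 2 to compound 4 (1.55 log units; beyond the scatter). For compound 4 the estimated half-life is 3 h, with an expected range of 1.2 h to 8 h.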

Compound 4, half-life: > 2 h
Compound 4: a limit, no number; the forecaster's own chance of this, stated with the estimate: 85%; the middle value lies beyond the limit too.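

At this place, on a carbonyl carbon whose other neighbours are amide-type nitrogen, 5-carboxy-2-fluorophenyl in place of 3-(propoxycarbonyl)phenyl gives an at least 23-fold higher number from compound 2 to compound 4 (1.37 log units; beyond the scatter) in this assay. Compound 4 gives > 2 h, which is a limit and not a number. The step from compound 1 to compound 4, fluoro in place of hydrogen on an aromatic carbon, cannot be read, because both values sit at one limit: the limit of > 2 h in this assay, at which 2 of the 4 values shown sit.

Any effect of the fluoro group on half-life remains open. So does the outcome with a primary amide or a methyl ester in place of the carboxylic acid.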